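Toward a Hydroxypiperidine Chain on the Shared Core

A few compounds are considered here, and "the series" means these few. Any claim that something is new, unique, unknown or untested is made for them only; others in the source may bear on it.

Three compounds built on one shared core differ only in the group on the saturated chain carbon bound to an aromatic nitrogen. Compound 1 `O=C1c2c[n+]([O-])c3ccccc3c2C(=O)c2c1c1ccccc1n2CCCCn1ccnc1` gives 210 nM in a functional assay on MDA-MB-231 cells (Homo sapiens) for cytotoxicity, read by MTT assay, with a stated time of 72 h; on this read-out higher numbers stand for weaker inhibition and lower numbers for stronger inhibition. Compound 2 `O=C1c2c[n+]([O-])c3ccccc3c2C(=O)c2c1c1ccccc1n2Cc1cn(CC(O)CO)nn1` gives 1290 nM, and compound 3 `CN1CCN(CCCCCn2c3c(c4ccccc42)C(=O)c2c[n+]([O-])c4ccccc4c2C3=O)CC1` gives 2270 nM. Compound 2 stands second highest of the three numbers: the step of a 6.1-fold higher number from compound 1 to compound 2 (0.79 log units; beyond the scatter) lies beyond the scatter, whereas the step of a 1.8-fold higher number from compound 2 to compound 3 (0.25 log units; within the scatter) does not.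

Compound 4 `O=C1c2c[n+]([O-])c3ccccc3c2C(=O)c2c1c1ccccc1n2CCCN1CCC(O)CC1` is not yet measured. Its difference from compound 2 reads (2-(4-hydroxypiperidin-1-yl)ethyl in place of 1-(2,3-dihydroxypropyl)-1H-1,2,3-triazol-4-yl on a saturated chain carbon bound to an aromatic nitrogen). The step that bears on this leads away from compound 2: the step of a 1.8-fold higher number from compound 2 to compound 3 (0.25 log units; within the scatter) placed a chain-borne saturated nitrogen ring on the same carbon and stayed within the scatter. The large step of an 11-fold higher number from compound 1 to compound 3 (1.03 log units; beyond the scatter) also brought in a group of that kind. Because compound 3 gives 2270 nM with a group of that kind, a step of similar size, within the scatter, is expected for a 1.2-fold higher number from compound 2 to compound 4 (0.09 log units; within the scatter). Compound 4 is therefore estimated at 1600 nM, with a range from 500 nM to 5000 nM.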

Compound 4, half-maximal inhibitory concentration: 280 nM
Beside the measured number, compound 4's estimate is 5.7-fold (0.76 log units) above it; the whole stated range lies above it.
By their numbers in this assay, from the lowest: compounds 1 and 4 (each within the scatter of the next); then compounds 2 and 3 (each within the scatter of the next).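

In this assay, the position on the saturated chain carbon bound to an aromatic nitrogen responds to a saturated nitrogen ring in more than one way: an 8.1-fold lower number from compound 3 to compound 4 (0.91 log units; beyond the scatter) lies beyond the scatter, so such a ring does not by itself bring the higher numbers. The change to 2-(4-hydroxypiperidin-1-yl)ethyl also gives a 4.6-fold lower number from compound 2 to compound 4 (0.66 log units; beyond the scatter), again beyond the scatter, the first step down from the 1-(2,3-dihydroxypropyl)-1H-1,2,3-triazol-4-yl group. With a 1.3-fold higher number from compound 1 to compound 4 (0.12 log units; within the scatter) within the scatter, the hydroxypiperidine chain and the imidazole chain cannot be told apart here.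

No measurement shown here accounts for these differences. Still open, from the compounds shown here alone, is whether the hydroxyl, the ring or the chain length carries the change, which a plain piperidine or a morpholine on the same propyl chain, or a longer chain bearing 4-hydroxypiperidin-1-yl, would help to separate.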